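The compounds below may be only part of what the source reports. "The series", "measured", "known", "first", "only" and "open" are said of these compounds alone.

Compound 1 `N#CN1CC(OCc2ccc(-c3ccccc3)cc2)C1`: in an assay on isolated protein for inhibition of N-acylethanolamine-hydrolyzing acid amidase (Homo sapiens), read by fluorescence, with a stated time of 90 min (on this read-out higher numbers stand for weaker inhibition and lower numbers for stronger inhibition), compound 1 gives 2.8 nM.
Compound 2 `COc1ccc(-c2ccc(COC3CN(C#N)C3)cc2)cc1`: in this assay compound 2 gives 0.94 nM.
Compound 3 `COc1ncccc1-c1ccc(COC2CN(C#N)C2)cc1`: in this assay compound 3 gives 5.8 nM.

Compound 4 `N#CN1CC(OCc2ccc(-c3cccnc3)cc2)C1` has not yet been measured. Its relation to compound 3 is hydrogen in place of methoxy on an aromatic carbon. The same kind of change, already measured, turns compound 2 into compound 1: hydrogen in place of methoxy on an aromatic carbon. That step gave a 3.0-fold higher number from compound 2 to compound 1 (0.47 log units; beyond the scatter). The places differ, though: in the measured pair the methoxy leaves a six-membered aromatic ring of carbon only, para to a large group, whereas in compound 3 it leaves a six-membered aromatic ring with one nitrogen, next to the ring nitrogen and ortho to a large group. How the core of compound 3 differs from that of compound 2 is not broken down here. Because compound 2 to compound 1 showed a 3.0-fold higher number from compound 2 to compound 1 (0.47 log units; beyond the scatter), a similar weakening is expected, giving a 2.6-fold higher number from compound 3 to compound 4 (0.41 log units; beyond the scatter). Compound 4 is therefore estimated at 15 nM in this assay.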

Compound 4, half-maximal inhibitory concentration: 12 nM
Beside the measured number, compound 4's estimate is 1.3-fold (0.10 log units) above it, and the stated range covers the measured number.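

In this assay, putting hydrogen in place of methoxy gives a 2.1-fold higher number from compound 3 to compound 4 (0.32 log units; beyond the scatter), and this step agrees with the one seen earlier on the other core: the same change on two cores in this assay, a 3.0-fold higher number (0.47 log units; beyond the scatter) from compound 2 to compound 1 and a 2.1-fold higher number (0.32 log units; beyond the scatter) from compound 3 to compound 4, 1.4-fold (0.16 log units) apart, within the scatter of two such steps

Within the data shown here, the change therefore carries over between these two cores with a similar size, but only two pairs show this, and they do not explain why the number moves. Among these compounds, putting pyridin-3-yl in place of phenyl gives a 4.3-fold higher number from compound 1 to compound 4 (0.63 log units; beyond the scatter), a different change with no second pair here to test whether it carries over.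

The compounds shown leave open whether an ethoxy group, a fluorine atom or an amine in place of the methoxy would give a similar number. They also leave open whether the methoxy step holds on other cores.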